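Removing One Chloro Group: From Compound 2 to Compound 3

The source may report more compounds than this note shows. Statements on the series, on what has been measured and on what is new or still open speak of the compounds shown alone.

Of the compounds shown here, two share one core and have been measured in a functional assay on HEp-2 cells (Homo sapiens) for inhibition, read by sulforhodamine B assay, with a stated time of 48 h; on this read-out lower numbers stand for stronger inhibition and higher numbers for weaker inhibition. Compound 1 `O=c1c(C2N=C(c3ccccc3)SS2)coc2ccc(Cl)cc12` carries a single chloro group on its fused six-membered carbon ring, and in this assay compound 1 gives 74900 nM. Compound 2 `O=c1c(C2N=C(c3ccccc3)SS2)coc2cc(Cl)c(Cl)cc12` carries two chloro groups on that ring, and in this assay compound 2 gives 98000 nM. Going by the values given here, compound 2 stands at the higher of the two numbers, but the single step in hand, a 1.3-fold higher number from compound 1 to compound 2 (0.12 log units; within the scatter), is within the scatter, so the two compounds cannot be told apart on these numbers.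

Compound 3 `O=c1c(C2N=C(c3ccccc3)SS2)coc2cc(Cl)ccc12` is not yet measured. It differs from compound 2 by hydrogen in place of chloro on an aromatic carbon, so it keeps one chloro group while the other is replaced by hydrogen. Among the compounds with values here, the only step that bears on this is the addition of a chloro group from compound 1 to compound 2, which stayed within the scatter. Taking a chloro group away is therefore expected to leave the number within the scatter as well, with no step in either direction beyond it, that is a 1.2-fold lower number from compound 2 to compound 3 (0.09 log units; within the scatter). For compound 3 the estimate in this assay is 80000 nM, with a range from 30000 nM to 200000 nM.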

Compound 3, half-maximal inhibitory concentration: > 100000 nM
Compound 3: a limit, no number; the forecaster's own chance of this, stated with the estimate: 10%; middle value at least 1.2-fold (0.09 log units) from the limit.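

Compound 3 gives > 100000 nM in this assay, and that value is a limit of the assay, not a number. Here hydrogen replaces the chloro group that compound 1 keeps, on an aromatic carbon ortho to the remaining chloro group, so this position is tested for the first time, and the result is an at least 1.0-fold higher number from compound 2 to compound 3 (0.00 log units; that floor lies within the scatter). Losing this chloro group therefore gives no sign of a lower number, but the true size of the step stays unknown, and the step may or may not go beyond the scatter, because the value of compound 3 is only a limit: the limit of > 100000 nM in this assay, at which 1 of the 3 values shown sits.

At this position the compounds shown carry only chloro or hydrogen, so it remains open whether another group there, such as a methoxy group, an amine or a carboxylic acid, would give a clearly lower number in this assay. Also open is how a compound with hydrogen at both of these ring carbons would read, since each compound shown keeps at least one chloro group.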